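Piperazine Nitrogen Substituent Swap in a Dithiocarbamate Benzamide Series

The compounds below may be only part of what the source reports. "The series", "measured", "known", "first", "only" and "open" are said of these compounds alone.

Of the compounds shown here, three sharing one core have been measured in a functional assay on HeLa cells (Homo sapiens) for antiproliferative activity, read by CCK-8 assay, with a stated time of 72 h, tested at 8 uM; on this read-out higher numbers stand for a stronger effect at the one concentration tested and lower numbers for a weaker effect. Compound 1 `Nc1ccccc1NC(=O)c1ccc(CSC(=S)N2CCN(Cc3ccccn3)CC2)cc1` gives 61.4%. Compound 2 `N#Cc1ccc(N2CCN(C(=S)SCc3ccc(C(=O)Nc4ccccc4N)cc3)CC2)cc1` gives 70.6%. Compound 3 `CN1CCN(C(=S)SCc2ccc(C(=O)Nc3ccccc3N)cc2)CC1` gives 75.7%, which sits at the top of the three numbers: the difference a number 14.3 percentage points higher from compound 1 to compound 3 (beyond the scatter) is beyond the scatter, whereas the difference a number 5.1 percentage points higher from compound 2 to compound 3 (within the scatter) stays within it, so compound 3 and compound 2 cannot be separated.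

Compound 4 `Nc1ccccc1NC(=O)c1ccc(CSC(=S)N2CCN(c3ncccn3)CC2)cc1` differs from compound 3 in one place: pyrimidin-2-yl in place of methyl on an amine nitrogen in a ring. The step that bears most directly on this change is a number 5.1 percentage points higher from compound 2 to compound 3 (within the scatter), in which an aromatic ring on the same ring nitrogen was exchanged for methyl with no shift beyond the scatter. The step of a number 9.2 percentage points higher from compound 1 to compound 2 (within the scatter) likewise shows an aromatic group on that nitrogen behaving much like the other substituents tried there. Compound 4 is therefore expected to give a number close to that of compound 3, with the step of a number 6.7 percentage points lower from compound 3 to compound 4 (within the scatter) estimated to remain within the scatter. For compound 4 the estimate in this assay is 69%, with a range from 56% to 80%.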

Compound 4, a percentage reported as inhibition, at one concentration (the size of the read-out at that concentration, not a potency): 73.9%
Compound 4: middle estimate off by 4.9 percentage points, on the low side; the range from low to high includes it.
By their numbers in this assay, from the lowest: compounds 1, 2, 4 and 3 (each within the scatter of the next, the first and the last beyond it).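

In this assay, the step of a number 1.8 percentage points lower from compound 3 to compound 4 (within the scatter) shows that this amine nitrogen accepts pyrimidin-2-yl, a six-membered aromatic ring with 2 hetero atoms, in place of methyl without a shift beyond the scatter, and the step of a number 3.3 percentage points higher from compound 2 to compound 4 (within the scatter) shows no separation from 4-cyanophenyl either. The step of a number 12.5 percentage points higher from compound 1 to compound 4 (beyond the scatter) places compound 4 with compound 3 as separated from compound 1, whereas compound 2 is not separated from compound 1. The data offer no measured basis for explaining these numbers.

The compounds shown leave open whether a carboxylic acid, a primary amine or a longer chain on this nitrogen would keep the read-out at this level. Going by these compounds, since each compound is read at one concentration, the numbers tell only how strong the effect is at that concentration, and how the compounds compare at other concentrations remains open.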